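One Change at the Carbonyl of Compound 1

A few compounds are considered here, and "the series" means these few. Any claim that something is new, unique, unknown or untested is made for them only; others in the source may bear on it.

Compound 1 `O=C(Nc1ccc(F)cc1)c1sc2ncccc2c1-c1ccc(Cl)cc1` was tested in an assay on cell membranes for displacement of a labelled ligand from metabotropic glutamate receptor 5 (Rattus norvegicus), tested at 1 uM (a higher number here means more inhibition at the concentration tested (going by the name of the read-out), a lower number less inhibition), where compound 1 gives 0%. Compound 3 `O=C(CCc1ccccc1)c1sccc1-c1ccc(F)cc1` gives 0%, level with compound 1 at the digits shown; together these are the lowest of the three numbers. Compound 2 `CC(=O)c1sc2ncccc2c1-c1ccccc1` gives 17%, a higher number that lies beyond the usual scatter. Compound 4 `O=C(Oc1ccc(F)cc1)c1sc2ncccc2c1-c1ccc(Cl)cc1` has not yet been measured. It differs from compound 1 in one place: 4-fluorophenoxy in place of (4-fluorophenyl)amino on a carbonyl carbon. Among the measured compounds shown here, no measured pair shows what this kind of change does here, so the expectation rests on compound 1 alone. Compound 4 is expected to give about 3%, within 0% to 15%. This estimate means a step of a number 3 percentage points higher from compound 1 to compound 4 (within the scatter), expected to be none beyond the scatter.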

Compound 4, a percentage reported as inhibition, at one concentration (the size of the read-out at that concentration, not a potency): 15%
For compound 4 the middle estimate is 12 percentage points below the measured one; measured number inside the range.
By their numbers in this assay, from the lowest: compounds 1 and 3 (each within the scatter of the next); then compounds 4 and 2 (each within the scatter of the next).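

In this assay the step of a number 15 percentage points higher from compound 1 to compound 4 (beyond the scatter) comes from 4-fluorophenoxy taking the place of (4-fluorophenyl)amino on a carbonyl carbon. This shows that the number at this position can move when only the link to the fluorophenyl ring changes, with the amide hydrogen lost and an oxygen gained. Nothing measured here explains the step. Still open, going by these compounds, is whether a sulfur atom or a methylene link in place of that oxygen would give a similar number. Also open, on these data alone, is whether an N-methyl amide, which likewise lacks the amide hydrogen, would match compound 4.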